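Swapping one end group on compound 1

This account rests on a few compounds, and the source may have more. Where it says the series, first, only, none or still open, it means among the compounds named here.

Among the measured compounds shown here, in a functional assay on HL-60 cells (Homo sapiens) for inhibition, read by CCK-8 assay, with a stated time of 48 h (a lower number here means a stronger inhibitor, a higher number a weaker inhibitor), compound 1 (`COc1ccc(Oc2ccc(C(C)C)cc2-c2ccsc2S(=O)(=O)NCCNC(=S)Nc2ccc([N+](=O)[O-])cc2)cc1OC`) gives 11200 nM as its half-maximal inhibitory concentration, the only exact number so far. In this assay compound 2 (`O=S(=O)(NCCNC(=S)Nc1cc(C(F)(F)F)cc(C(F)(F)F)c1)c1ccc(-c2ccccc2OCc2cccc(O)c2)s1`) gives > 50000 nM as a result, which is a limit of the assay and not a number. Compound 3 (`COc1ccc(Oc2ccc(C(C)C)cc2-c2ccsc2S(=O)(=O)NCCNC(=O)Nc2cc(Cl)cc(Cl)c2)cc1OC`) keeps the core of compound 1, and the change a group of 11 heavy atoms (7 carbon, 1 nitrogen, 1 oxygen, 2 chlorine; one six-membered aromatic ring of carbon only) in place of a group of 12 heavy atoms (7 carbon, 2 nitrogen, 2 oxygen, 1 sulfur; one six-membered aromatic ring of carbon only), on an amine nitrogen brings in (3,5-dichlorophenyl)carbamoyl on an amine nitrogen. For the measured compounds named here, no measured pair shows what such a swap does, so in this assay no step beyond the usual scatter is expected, in either direction. Going by the values given here, the only anchor is compound 1 at 11200 nM as its measured value, which leaves the expectation wide. The expected change is a 1.1-fold higher number from compound 1 to compound 3 (0.03 log units; within the scatter) as an estimate. For compound 3 the estimated value is 12000 nM with an expected range from 3500 nM to 42000 nM in this measurement.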

Compound 3, half-maximal inhibitory concentration: 6500 nM
The estimate for compound 3 lay 1.8-fold (0.27 log units) above the measured number; low and high end bracket the measured number.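

Among the compounds shown here, this is the first measured pair at this place, on an amine nitrogen, and in this assay it gives a 1.7-fold lower number from compound 1 to compound 3 (0.24 log units; within the scatter). The entering (3,5-dichlorophenyl)carbamoyl carries two chlorine atoms and one oxygen where the group it replaces carries sulfur and more nitrogen and oxygen, yet the step stays within the scatter, so this large change in atoms leaves the read-out without a clear shift. Compound 2 differs in more than one place and offers no comparison, and its result is a limit and not a number: the limit of > 50000 nM in this assay, at which 1 of the 3 values shown sits.

From the compounds shown here alone, the ring substituents and the exchange of sulfur for oxygen changed together here, so the share of each remains open. Also open, going by these compounds, is what a group with no aromatic ring, such as a simple acetyl, would do on the same amine nitrogen.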